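The source may report more compounds than this note shows. Statements on the series, on what has been measured and on what is new or still open speak of the compounds shown alone.

Compound 2 `O=C(Nc1ccccc1Cl)N1CCC(c2nc(-c3ccc4ccccc4n3)no2)CC1` gives 510 nM in a functional assay on Shh Light II cells (Mus musculus) for inhibition, read by a luciferase reporter (a higher number here means a weaker inhibitor, a lower number a stronger inhibitor), the lowest of the three numbers shown. Compound 1 `C[C@@H]1C[C@H](c2nc(-c3ccc4ccccc4n3)no2)CCN1C(=O)Nc1ccccc1Cl` gives 2400 nM; the step of a 4.7-fold lower number from compound 1 to compound 2 (0.67 log units; beyond the scatter) concerns only a methyl on the saturated ring. Among the measured compounds shown here, compound 3 `O=C(NC1CCNCC1)N1CCC(c2nc(-c3ccc4ccccc4n3)no2)CC1` gives 2500 nM; the step of a 4.9-fold higher number from compound 2 to compound 3 (0.69 log units; beyond the scatter) is the only one that touches the group on the amide-type nitrogen, and it shows that losing the 2-chlorophenyl weakens inhibition. Compound 4 `CC(C)c1ccccc1NC(=O)N1CCC(c2nc(-c3ccc4ccccc4n3)no2)CC1` differs from compound 2 in one place: isopropyl in place of chloro on an aromatic carbon. For the measured compounds named here, no measured step exchanges one group on that aromatic ring for another, so the direction is open; a modest shift is expected, more likely a small loss. Compound 4 is estimated at 1000 nM, with a range from 300 nM to 3500 nM, an expected step of a 2.0-fold higher number from compound 2 to compound 4 (0.29 log units; within the scatter).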

Compound 4, half-maximal inhibitory concentration: 480 nM
The estimate for compound 4 lay 2.1-fold (0.32 log units) above the measured number; low and high end bracket the measured number.
By their numbers in this assay, from the lowest: compounds 4 and 2 (each within the scatter of the next); then compounds 1 and 3 (each within the scatter of the next).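

Putting isopropyl where chloro stood on the aromatic ring gives a 1.1-fold lower number from compound 2 to compound 4 (0.03 log units; within the scatter), so at this place a group of three carbons serves as well as a single chlorine atom. The 2-isopropylphenyl group also keeps the advantage over piperidin-4-yl, with a 5.2-fold lower number from compound 3 to compound 4 (0.72 log units; beyond the scatter), so that advantage does not depend on chlorine. As far as these compounds go, how a methoxy group, an amine or a plain hydrogen would behave at this carbon stays open. No measurement shown gives a reason for these results.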